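The source may report more compounds than this note shows. Statements on the series, on what has been measured and on what is new or still open speak of the compounds shown alone.

Measured compounds:
compound 1, `CCC(=O)Nc1ccc(S(=O)(=O)Oc2ccccc2I)cc1`, gives 11000 nM in a functional assay on HT-29 cells (Homo sapiens) for antiproliferative activity, read by sulforhodamine B assay, with a stated time of 48 h; a lower number here means a stronger inhibitor, a higher number a weaker inhibitor.
compound 2, `CC(C)(C)C(=O)Nc1ccc(S(=O)(=O)Oc2ccccc2I)cc1`, gives 9500 nM in this assay.

Among the measured compounds shown here, compound 2 shows the lowest of the two numbers, but its only neighbour is compound 1, and the move a 1.2-fold lower number from compound 1 to compound 2 (0.06 log units; within the scatter) lies within the scatter, so no order can be read between them. Compound 3, `CCCNC(=O)Nc1ccc(S(=O)(=O)Oc2ccccc2I)cc1`, differs from compound 2 by propylamino in place of tert-butyl on a carbonyl carbon. For the measured compounds named here, the one measured step that bears on this place, a 1.2-fold lower number from compound 1 to compound 2 (0.06 log units; within the scatter), exchanged one group on that carbonyl carbon for another without a change beyond the scatter. Nothing measured here tells how an amino group on that carbonyl behaves, so the expectation rests on that single indifferent step. In this assay compound 3 is therefore expected near compound 2, with a 1.1-fold higher number from compound 2 to compound 3 (0.02 log units; within the scatter) as the estimated step. The estimate for compound 3 is 10000 nM, within 4000 nM to 25000 nM.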

Compound 3, half-maximal inhibitory concentration: 6800 nM
For compound 3 the middle estimate is 1.5-fold (0.17 log units) above the measured one, and the stated range covers the measured number.
By their numbers in this assay, from the lowest: compounds 3, 2 and 1 (each within the scatter of the next).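

In this assay, the exchange of tert-butyl for propylamino on a carbonyl carbon brings in a nitrogen and a hydrogen-bond donor, yet it amounts only to a 1.4-fold lower number from compound 2 to compound 3 (0.15 log units; within the scatter). The exchange of ethyl for propylamino at the same place amounts to a 1.6-fold lower number from compound 1 to compound 3 (0.21 log units; within the scatter), so neither step separates propylamino from the carbon-only group it replaces, and the three groups cannot be put in order at this place. Nothing shown here offers an explanation for this result.

The compounds shown cover only these three uncharged groups, so they leave open whether a carboxylic acid or a primary amine at the end of the chain would move the number beyond the scatter. From the compounds shown here alone, a much longer chain or a phenyl group on the carbonyl carbon also remains untested by these compounds.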